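The compounds below may be only part of what the source reports. "The series", "measured", "known", "first", "only" and "open" are said of these compounds alone.

Measured compounds in an ADME assay on cells (Mus musculus, strain Balb/c) for cytotoxicity, read by MTT assay, with a stated time of 48 h; a lower number here means that less compound is tolerated, a higher number that more compound is tolerated:
compound 1, `COc1ccc(C(/C=C/c2ccc(F)cc2)=N/O)cc1`, 13500 nM
compound 2, `COc1ccc(C(/C=C/c2cccs2)=N/O)cc1`, 10600 nM
compound 3, `COc1ccc(C(/C=C/c2ccccc2)=N/O)cc1`, 28600 nM

Compound 2 gives the lowest of the three numbers, though its gap to compound 1 lies within the scatter and the two cannot be ordered; compound 3 stands apart from it, with a 2.7-fold higher number from compound 2 to compound 3 (0.43 log units; beyond the scatter). The unmeasured compound 4, `O/N=C(\C=C\c1cccs1)c1ccc(Cl)cc1`, differs from compound 2 by chloro in place of methoxy on an aromatic carbon. Among the measured compounds shown here, no measured step touches that ring. The two steps known, a 2.1-fold higher number from compound 1 to compound 3 (0.33 log units; beyond the scatter) and the one above, both concern other parts of the shared core, and each is modest. For the measured compounds named here, a change on the ring that has not yet been varied carries no direct precedent, so no step beyond the scatter is expected. The estimate for compound 4 in this assay is 9500 nM (range 4000 nM to 22000 nM). Accordingly, a 1.1-fold lower number from compound 2 to compound 4 (0.05 log units; within the scatter) is expected.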

Compound 4, half-maximal cytotoxic concentration: 11800 nM
Compound 4: middle estimate off by 1.2-fold (0.09 log units), on the low side, and the stated range covers the measured number.
By their numbers in this assay, from the lowest: compounds 2, 4 and 1 (each within the scatter of the next); then compound 3.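

In this assay, among the compounds shown here, the earlier compounds all carry methoxy on the aromatic carbon para to a large group, so this position had no step of its own. Chloro in place of methoxy gives a 1.1-fold higher number from compound 2 to compound 4 (0.05 log units; within the scatter), so with the thiophen-2-yl chain these two groups cannot be told apart here. No measured evidence bears on why they read alike.

Still open, going by these compounds, is whether the same swap reads alike alongside the phenyl chain of compound 3. On these data alone, how an amine or a carboxylic acid at this position would read also remains open.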